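Mirror-image stereochemistry in a cyclic acetate series

The source may hold more compounds than are shown below. What is called first, only, known or untested is meant among the compounds shown, and "the series" means these compounds.

Of the compounds shown here, two have been measured so far in a functional assay on A2780 cells (Homo sapiens) for antiproliferative activity, read by sulforhodamine B assay, with a stated time of 48 h; on this read-out higher numbers stand for weaker inhibition of growth and lower numbers for stronger inhibition of growth. Compound 1 `CC(=O)OC1OC=CC2C1CC[C@H]2O` gives 15000 nM. Compound 2 `CC(=O)O[C@@H]1OC=C[C@@H]2[C@H]1[C@@H](C)C[C@H]2O[Si](c1ccccc1)(c1ccccc1)C(C)(C)C` gives 1590 nM, the lower of the two numbers, beyond the scatter of compound 1, so compound 2 stands as the stronger grower inhibitor of the pair. Compound 3 `CC(=O)O[C@H]1OC=C[C@H]2[C@@H]1[C@H](C)C[C@H]2O[Si](c1ccccc1)(c1ccccc1)C(C)(C)C` has not yet been measured. It differs from compound 2 only in configuration: the two compounds have the same atoms and bonds and differ only in configuration as drawn: 4 of 5 stereo elements differ; a stereocentre at a saturated ring carbon is drawn S in compound 2 and R in compound 3; a stereocentre at a saturated ring carbon is drawn R in compound 2 and S in compound 3; a stereocentre at a saturated ring carbon is drawn R in compound 2 and S in compound 3; a stereocentre at a saturated ring carbon is drawn S in compound 2 and R in compound 3. Among the compounds with values here, no step between two measured compounds involves a change of configuration alone, so there is no measured guide for this kind of change. Inverting most of the ring stereocentres usually alters activity, and the direction here is uncertain. Compound 3 is expected to give about 4000 nM, within a wide range from 1000 nM to 20000 nM. This estimate corresponds to a weakening step a 2.5-fold higher number from compound 2 to compound 3 (0.40 log units; beyond the scatter), with the possibility that no difference beyond the scatter appears.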

Compound 3, concentration for 50% growth inhibition: 1240 nM
Compound 3: middle estimate off by 3.2-fold (0.51 log units), on the high side; the range from low to high includes it.
By their numbers in this assay, from the lowest: compounds 3 and 2 (each within the scatter of the next); then compound 1.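

In this assay, inverting four of the five stereo elements gives a 1.3-fold lower number from compound 2 to compound 3 (0.11 log units; within the scatter), so this assay does not separate the two compounds. Within the data shown here, this is the first measured case of a change in configuration alone, and here such a change leaves the growth-inhibition read-out unchanged within the scatter. No change of atoms or bonds enters this comparison, so the pair speaks only to the drawn arrangement: the fact that compounds 2 and 3 differ only in the configuration as drawn.

Going by these compounds, the pair inverts these stereocentres together, so the effect of inverting any one alone remains open, as does whether the same result would hold for compounds carrying a free hydroxyl rather than the tert-butyldiphenylsilyl ether. It is also unknown how this assay would read an amine or a carboxylic acid in place of the acetate.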